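Working notes on the series: carbamoyl to 2-aminoethyl

This account rests on a few compounds, and the source may have more. Where it says the series, first, only, none or still open, it means among the compounds named here.

Three compounds of this series have numbers in a functional assay on the whole organism (Tail, strain ICR) with Mus musculus as the target, in the tail flick test, with a stated time of 30 min, at a dose of 25 umol/kg by the oral route; a lower number here means a weaker effect, a higher number a stronger effect of the compound at the dose given. Compound 1 `CSCC[C@H](NC(=O)CN(c1ncnc2c1ncn2C1CCCCO1)C1CC1)C(=O)OCc1ccccc1` gives 30%. Compound 2 `NC(=O)CC[C@H](NC(=O)CN(c1nc(Cl)nc2[nH]cnc12)C1CC1)C(=O)O` gives 33.1%, and compound 3 `NC(=O)CC[C@H](NC(=O)CN(c1nc(Cl)nc2[nH]cnc12)C1CC1)C(=O)OCc1ccccc1` gives 30.8%. Compound 2 carries the top number of the three, but its gaps to compound 3 and to compound 1 are both within the scatter, so the three are not separable on these data. Among the measured compounds shown here, the single step measured between neighbours, a number 2.3 percentage points lower from compound 2 to compound 3 (within the scatter), also stays within the scatter.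

Compound 4 `NCCCC[C@H](NC(=O)CN(c1nc(Cl)nc2[nH]cnc12)C1CC1)C(=O)O` has not yet been measured in this assay. It differs from compound 2 by 2-aminoethyl in place of carbamoyl on a saturated chain carbon, three bonds along the chain from an amide-type nitrogen and a carbonyl carbon. For the measured compounds named here, no measured step touches this part of the structure: the only step known changes the ester end, and it gave nothing beyond the scatter. There is thus no measured ground for expecting a change in either direction; the expected step from compound 2 to compound 4, a number 1.1 percentage points lower from compound 2 to compound 4 (within the scatter), is therefore none beyond the scatter, and the range around it is kept wide for want of any comparable step.

For compound 4 in this assay the estimate is 32%, expected to lie between 18% and 46%.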

Compound 4, a percentage reported as activity, at one dose (the size of the read-out at that dose, not a potency): 31.2%
For compound 4 the middle estimate is 0.8 percentage points above the measured one; the range from low to high includes it.
By their numbers in this assay, from the lowest: compounds 1, 3, 4 and 2 (each within the scatter of the next).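

Among the compounds shown here, the first reading at this position comes from this assay: 2-aminoethyl in place of carbamoyl on a saturated chain carbon, three bonds along the chain from an amide-type nitrogen and a carbonyl carbon, gives a number 1.9 percentage points lower from compound 2 to compound 4 (within the scatter). The earlier step touched only the ester end, so this result extends the picture to a second part of the structure, and here too the change stays within the scatter. Read with the cut one bond further out, as 2-carbamoylethyl to 4-aminobutyl, it shows that this exchange of side chains leaves no separable difference at the dose given, and nothing at hand offers an explanation for that outcome.

On these data alone, whether a carboxylic acid, a hydroxyl group or a longer chain at this place would separate from compound 2 remains open, as does whether a benzyl on the ester oxygen would behave with the 4-aminobutyl chain as it does in a number 2.3 percentage points lower from compound 2 to compound 3 (within the scatter). As far as these compounds go, all these numbers are read-outs at one dose, so any difference in potency between compound 2 and compound 4 also remains open.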